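A few compounds are considered here, and "the series" means these few. Any claim that something is new, unique, unknown or untested is made for them only; others in the source may bear on it.

Measured in a physicochemical assay for lipophilicity, read by HPLC, at pH 7.4; a lower number here means a more polar compound, a higher number a more lipophilic compound:
compound 1 `O=C(O)CNC(=O)COc1ccc([C@H]2CC[C@]3(CC2)OOC2(O3)C3CC4CC(C3)CC2C4)cc1`: 3
compound 2 `O=C(O)c1cc([C@H]2CC[C@]3(CC2)OOC2(O3)C3CC4CC(C3)CC2C4)ccc1O`: 3
compound 3 `O=C(O)COc1ccc([C@H]2CC[C@]3(CC2)OOC2(O3)C3CC4CC(C3)CC2C4)cc1C(=O)O`: 1.9

Compound 1 and compound 2 show the same number, and compound 3 shows a lower one. Compound 4 `CCOC(=O)COc1ccc([C@H]2CC[C@]3(CC2)OOC2(O3)C3CC4CC(C3)CC2C4)cc1` keeps the core of compound 1 but carries ethoxy in place of (carboxymethyl)amino on a carbonyl carbon.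

Going by the values given here, only one measured step bears on this, and only loosely: a number 1.10 log units lower from compound 2 to compound 3 (beyond the scatter), where carboxymethyl replaces hydrogen on an oxygen on an aromatic ring. The change to compound 4 instead removes a carboxymethyl, so a higher number in this assay is expected, of similar or somewhat larger size. Among the compounds with values here, no measured compound resembles compound 4 at this end, so the range stays wide.

The expected change is a number 1.40 log units higher from compound 1 to compound 4 (beyond the scatter). Compound 4 is estimated at 4.4, with an expected range from 3.6 to 5.2.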

Compound 4, distribution coefficient: > 5.3
Compound 4: only a limit was reported; the forecaster's own chance of this, stated with the estimate: 5%; at least 0.90 log units between middle value and limit.
By their numbers in this assay, from the lowest: compound 3; then compounds 1 and 2 (each within the scatter of the next). At a limit, above all of these: compound 4.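

In this assay, ethoxy in place of (carboxymethyl)amino on a carbonyl carbon gives a number at least 2.30 log units higher from compound 1 to compound 4 (beyond the scatter). Going by these compounds alone, the only earlier step concerned an oxygen on an aromatic ring, so this is the first sign that a change on this carbonyl carbon can also move the reading by a large amount. The reading for compound 4 is a limit of the assay and not a number: the limit of > 5.3 in this assay, at which 1 of the 4 values shown sits.

The compounds shown leave open how methylamino or propoxy on the same carbonyl carbon would read. They therefore cannot tell which part of the (carboxymethyl)amino group goes with this step.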